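Aryl swap on a succinimide piperazine amide in electroshock

A few compounds are considered here, and "the series" means these few. Any claim that something is new, unique, unknown or untested is made for them only; others in the source may bear on it.

Measured so far, in a functional assay on the whole organism (strain Swiss) with Mus musculus as the target, in the maximal electroshock model, with a stated time of 0.5 h, at a dose of 300 mg/kg by the intraperitoneal route; a higher number here means a stronger effect of the compound at the dose given, a lower number a weaker effect:
compound 1, `CCC(C(=O)N1CCN(c2cccc(F)c2)CC1)N1C(=O)CCC1=O`, gives 100%;
compound 2, `CC(C(=O)N1CCN(c2cccc(F)c2)CC1)N1C(=O)CCC1=O`, gives 50%;
compound 3, `CCC(C(=O)N1CCN(c2cccc(C(F)(F)F)c2)CC1)N1C(=O)CCC1=O`, gives 50%.

Compound 1 stands highest of the three, and both other numbers lie the same distance below it, beyond the scatter. Its two neighbours each differ in one place: hydrogen in place of methyl on the chain gave a number 50 percentage points lower from compound 1 to compound 2 (beyond the scatter), and trifluoromethyl in place of fluoro on the aromatic carbon gave a number 50 percentage points lower from compound 1 to compound 3 (beyond the scatter).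

Compound 4, `CCC(C(=O)N1CCN(c2ccc(Cl)cc2)CC1)N1C(=O)CCC1=O`, is not yet measured. Against compound 1 the change is 4-chlorophenyl in place of 3-fluorophenyl on an amine nitrogen in a ring.

Going by the values given here, only the step to compound 3 touches the same part of the structure, and that step was large and downward; nothing in the data shows a change at the aryl group that held or raised the number. Compound 4 is therefore expected to give 60%, within 25% to 100%. That expectation means a step of a number 40 percentage points lower from compound 1 to compound 4 (beyond the scatter).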

Compound 4, a percentage reported as activity, at one dose (the size of the read-out at that dose, not a potency): 0%
Estimate against measurement, compound 4: 60 percentage points above, outside the stated range (below it).
By their numbers in this assay, from the lowest: compound 4; then compounds 2 and 3 (each within the scatter of the next); then compound 1.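

In this assay, the aryl group on the ring amine nitrogen turns out to decide whether any effect remains at this dose: 4-chlorophenyl in place of 3-fluorophenyl gives a number 100 percentage points lower from compound 1 to compound 4 (beyond the scatter), although the two groups match in their counts of heavy atoms, donors and acceptors. The earlier aryl change, a number 50 percentage points lower from compound 1 to compound 3 (beyond the scatter), left part of the effect in place, whereas compound 4 gives 0% and so shows that a change at this position can remove it entirely. Nothing measured here bears on why this swap has such a result.

The step changes both the halogen and its place on the phenyl ring, so the compounds shown leave open which of the two matters. A 3-chlorophenyl or a 4-fluorophenyl group on the same nitrogen would separate them, and an unsubstituted phenyl would show what either halogen adds.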